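This account rests on a few compounds, and the source may have more. Where it says the series, first, only, none or still open, it means among the compounds named here.

For the measured compounds named here, only two compounds have numbers so far in a functional assay on the whole organism (spleen, spleen, strain LEW) for inhibition, with Rattus norvegicus as the target, with a stated time of 4 days; on this read-out lower numbers stand for an effect already at smaller amounts and higher numbers for an effect only at larger amounts of compound. Compound 1 (`CCc1cc(CN2CC(C(=O)O)C2)sc1-c1noc(-c2ccc(Oc3ccccc3)cc2)n1`) gives 0.41 mg/kg, and compound 2 (`CCc1cc(CN2CC(C(=O)O)C2)sc1-c1ncc(-c2ccc(OC(C)C)c(C)c2)s1`) gives 0.07 mg/kg. Compound 2 therefore holds the lower of the two numbers, and its distance from compound 1 lies beyond the scatter. The two are not related by a single change, so this gap says nothing about any one group.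

Compound 3 (`CCc1cc(-c2cnc(-c3sc(CN4CC(C(=O)O)C4)cc3CC)s2)ccc1OC(C)C`) departs from compound 2 in one place: methyl in place of hydrogen on a saturated chain carbon bound to an aromatic carbon. Cut one bond further out, the same difference reads methyl to ethyl. Going by the values given here, no measured pair shows the effect of this change in this assay, so the expectation starts from compound 2 at 0.07 mg/kg and from the single added carbon. No step beyond the scatter is expected, and neither direction is favoured. The expected change is a 1.1-fold higher number from compound 2 to compound 3 (0.06 log units; within the scatter). For compound 3 the estimated value is 0.08 mg/kg, with an expected range from 0.025 mg/kg to 0.25 mg/kg.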

Compound 3, dose for 50% inhibition: 0.16 mg/kg
Compound 3: middle estimate off by 2.0-fold (0.30 log units), on the low side; the range from low to high includes it.
By their numbers in this assay, from the lowest: compound 2; then compound 3; then compound 1.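

In this assay, for the compounds shown here, this is the first single change that can be read, namely methyl in place of hydrogen on a saturated chain carbon bound to an aromatic carbon, and it gives a modest step that lies beyond the scatter (a 2.3-fold higher number from compound 2 to compound 3 (0.36 log units; beyond the scatter)). The earlier gap joined two compounds that differ in more than one place and could not be assigned to any one group, whereas this step rests on one added carbon, so this position does respond to the change from methyl to ethyl, and the response runs towards a higher number. Nothing measured here accounts for the step.

Going by these compounds, a single step at this position gives a direction for this one change, not a trend, so it remains open whether a longer chain such as propyl, or a methoxy group, would carry the rise further or reverse it. On these data alone, it also remains open whether the same change would give a step of similar size on the core of compound 1.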